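The source may report more compounds than this note shows. Statements on the series, on what has been measured and on what is new or still open speak of the compounds shown alone.

Measured in a functional assay on FM3A cells (Mus musculus) for inhibition, read by cell counting, with a stated time of 2 days; on this read-out lower numbers stand for stronger inhibition and higher numbers for weaker inhibition:
compound 1 `C=C(Br)C(=O)Nc1cccc(-c2cn3c(-c4ccccc4)csc3n2)c1` — 1300 nM
compound 2 `COc1ccc(-c2csc3nc(-c4cccc(N)c4)cn23)cc1` — 11000 nM
compound 3 `C=C(Br)C(=O)Nc1cccc(-c2cn3c(-c4ccc(Cl)cc4)csc3n2)c1` — 1100 nM

Compound 3 gives 1100 nM in this assay; its gap to compound 1 lies within the scatter, its gap to compound 2 beyond it. Compound 4 `C=C(Br)C(=O)Nc1cccc(-c2cn3c(-c4ccc(OC)cc4)csc3n2)c1` differs from compound 3 by methoxy in place of chloro on an aromatic carbon. Within the data shown here, the only measured step at this position is a 1.2-fold lower number from compound 1 to compound 3 (0.07 log units; within the scatter), which changed nothing beyond the scatter. Among the measured compounds shown here, compound 2 carries the methoxy group but also differs elsewhere from compound 4, so its value gives no direct step here. The expectation for compound 4 is therefore no step beyond the scatter, a 1.3-fold higher number from compound 3 to compound 4 (0.10 log units; within the scatter). Compound 4 is estimated at 1400 nM, with a range from 600 nM to 3500 nM.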

Compound 4, half-maximal inhibitory concentration: 620 nM
For compound 4 the middle estimate is 2.3-fold (0.35 log units) above the measured one; the measured number falls inside the stated range.
By their numbers in this assay, from the lowest: compounds 4, 3 and 1 (each within the scatter of the next, the first and the last beyond it); then compound 2.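

At this place, para to a large group, methoxy and chloro cannot be told apart (a 1.8-fold lower number from compound 3 to compound 4 (0.25 log units; within the scatter)). Set against hydrogen, however, methoxy gives the first step here beyond the scatter (a 2.1-fold lower number from compound 1 to compound 4 (0.32 log units; beyond the scatter)), though a modest one, while the (1-bromoethenyl)carbonyl group on the nitrogen weighs far more (an 18-fold lower number from compound 2 to compound 4 (1.25 log units; beyond the scatter)). Nothing available explains these differences in size.

On these data alone, whether an amine, a hydroxyl or a longer alkoxy chain at this place would differ from methoxy stays open. Also open, as far as these compounds go, is whether the step from hydrogen to methoxy holds with another group on that nitrogen.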